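Amino for chloro on the core of compound 1

The source may report more compounds than this note shows. Statements on the series, on what has been measured and on what is new or still open speak of the compounds shown alone.

Compound 1 `ClCc1ccccc1Cn1cnc2c(Cl)nc(Cl)nc21` gives 1990 nM in a functional assay on T47D cells (Homo sapiens) for cytotoxicity, read by sulforhodamine B assay, with a stated time of 48 h (on this read-out higher numbers stand for weaker inhibition of growth and lower numbers for stronger inhibition of growth), the highest of the three numbers measured. Compound 2 `ClCc1cccc(Cn2cnc3ncnc(Cl)c32)c1` gives 210 nM and compound 3 `ClCc1cccc(Cn2cnc3nc(Cl)nc(Cl)c32)c1` gives 220 nM in this assay; each stands well below compound 1, beyond the scatter. Among the measured compounds shown here, the only single-point step within the measured set is a 1.0-fold higher number from compound 2 to compound 3 (0.02 log units; within the scatter), so adding a chloro to the six-membered ring of the shared core left the read-out unchanged. Compound 4 `Nc1nc(Cl)c2ncn(Cc3ccccc3CCl)c2n1` differs from compound 1 by amino in place of chloro on an aromatic carbon. For the measured compounds named here, no measured pair exchanges chloro for amino, so nothing bears directly on this change; the one step that alters the same ring, compound 2 to compound 3, stayed within the scatter. With no precedent in either direction, the expectation for this assay is no step beyond the scatter, with a wide range. Compound 4 is therefore expected near 2000 nM, between 500 nM and 8000 nM. The step expected from compound 1 is a 1.0-fold higher number from compound 1 to compound 4 (0.00 log units; within the scatter).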

Compound 4, concentration for 50% growth inhibition: 24000 nM
For compound 4 the middle estimate is 12-fold (1.08 log units) below the measured one; the whole stated range lies below it.
By their numbers in this assay, from the lowest: compounds 2 and 3 (each within the scatter of the next); then compound 1; then compound 4.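

Unlike the step from hydrogen to chloro at this same carbon (a 1.0-fold higher number from compound 2 to compound 3 (0.02 log units; within the scatter)), which lay within the scatter, this position proves sensitive to the group it carries in this assay. Amino in place of chloro on the aromatic carbon between two ring nitrogen atoms gives a 12-fold higher number from compound 1 to compound 4 (1.08 log units; beyond the scatter) and so weakens growth inhibition, a result resting on this one pair. No supporting data bear on why the read-out moves with this exchange.

As far as these compounds go, whether amino has a similar effect on the core of compound 2 and compound 3, with its chloromethyl group placed differently, remains open. Also open, from the compounds shown here alone, is whether methylamino, methoxy or hydroxyl at this carbon would track amino or chloro.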